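From compound 2 to compound 3: a methoxy step

The source may report more compounds than this note shows. Statements on the series, on what has been measured and on what is new or still open speak of the compounds shown alone.

Measured in a functional assay on FM3A cells (Mus musculus) for antiproliferative activity, read by cell counting, with a stated time of 2 days; on this read-out lower numbers stand for stronger inhibition and higher numbers for weaker inhibition:
- compound 1 `COc1ccc(C(=O)c2sc(Nc3ccc(Cl)cc3)nc2N)cc1`: > 10000 nM, a limit
- compound 2 `Nc1nc(Nc2ccc(F)cc2)sc1C(=O)c1ccccc1`: > 10000 nM, a limit

Compound 2 gives only a limit, > 10000 nM, and no number. Compound 1 also gives only a limit, > 10000 nM. The evidence so far therefore reads: the limit of > 10000 nM in this assay, at which 2 of the 2 values shown sit.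

Compound 3 `COc1ccc(C(=O)c2sc(Nc3ccc(F)cc3)nc2N)cc1` differs from compound 2 by one change: methoxy in place of hydrogen on an aromatic carbon. Methoxy takes the place of hydrogen on an aromatic carbon, para to a large group, so that phenyl becomes 4-methoxyphenyl.

For the measured compounds named here, no step between measured compounds is available. In this assay, the expectation is therefore no step beyond the scatter. The expected change is a number no higher from compound 2 to compound 3 (the limit leaves the size open). Compound 3 is estimated at 10000 nM, with an expected range of 4000 nM to 25000 nM.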

Compound 3, half-maximal inhibitory concentration: > 10000 nM
Compound 3: a limit, no number; the forecaster's own chance of this, stated with the estimate: 75%; the middle value lies on the limit itself.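

For the compounds shown here, compound 1, compound 2 and compound 3 all give only limits, so neither the step from compound 2 to compound 3 nor the one from compound 1 to compound 3 can be read. The compounds shown leave open whether methoxy in place of hydrogen, or fluoro in place of chloro, alters antiproliferative activity.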